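Lipophilicity notes: fluoro for cyano on the phenyl

This account rests on a few compounds, and the source may have more. Where it says the series, first, only, none or still open, it means among the compounds named here.

Measured so far:
compound 1 `O=C(Nc1cnc2[nH]ncc2c1)[C@H]1CCCN1C(=O)C1(c2cccc(Cl)c2)CCCC1`: 4.9
compound 2 `O=C(Nc1ccc2[nH]nnc2c1)[C@H]1CCCN1C(=O)C1(c2cccc(Cl)c2)CCCC1`: 5.2
compound 3 `N#Cc1ccc(C2(C(=O)N3CCC[C@@H]3C(=O)Nc3ccc4[nH]ncc4n3)CCC2)cc1`: 3.4

In a physicochemical assay for lipophilicity, at pH 7.4 (a lower number here means a more polar compound, a higher number a more lipophilic compound), compound 3 stands lowest of the three, with compound 1 nearest and compound 2 furthest, both beyond the scatter. Compound 4 `O=C(Nc1ccc2[nH]ncc2n1)[C@H]1CCCN1C(=O)C1(c2ccc(F)cc2)CCC1` differs from compound 3 only by fluoro in place of cyano on an aromatic carbon. Within the data shown here, the one measured step, a number 0.30 log units higher from compound 1 to compound 2 (within the scatter), concerns the amide-side ring system and not the phenyl substituent, so no measured step bears directly on this change. On general experience with this assay a rise beyond the scatter is expected for fluoro in place of cyano on an aromatic carbon. Compound 4 is therefore estimated at 4.2, range 3.7 to 4.7, an expected step of a number 0.80 log units higher from compound 3 to compound 4 (beyond the scatter).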

Compound 4, distribution coefficient: 4.1
Beside the measured number, compound 4's estimate is 0.10 log units above it; low and high end bracket the measured number.
By their numbers in this assay, from the lowest: compound 3; then compound 4; then compounds 1 and 2 (each within the scatter of the next).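

In this assay, among these compounds, the change from 4-cyanophenyl to 4-fluorophenyl gives a number 0.70 log units higher from compound 3 to compound 4 (beyond the scatter) and is the only measured step at this position, since the earlier step concerned the group on the amide-type nitrogen. The substituent on this aromatic carbon, para to a large group, therefore moves the read-out beyond the scatter, though the step is modest. Nothing available explains the size of this step. As far as these compounds go, whether an amine, a carboxylic acid or a longer chain at this position would move the read-out in the same direction stays open. Also open, from the compounds shown here alone, is whether the same change would give a similar step on the core of compound 1.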